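A few compounds are considered here, and "the series" means these few. Any claim that something is new, unique, unknown or untested is made for them only; others in the source may bear on it.

Series notes, a functional assay on the whole organism with Mus musculus as the target, in the writhing test, at a dose of 100 mg/kg by the intraperitoneal route; a lower number here means less inhibition, a higher number more inhibition at the dose given (going by the name of the read-out):

- compound 1 `Brc1ccccc1COc1nc2ccccc2s1`: 51.9%
- compound 2 `c1ccc(COc2nc3ccccc3s2)cc1`: 51.9%
- compound 3 `FC(F)(F)c1ccc(COc2nc3ccccc3s2)cc1`: 99.6%

Compound 2 stands level with compound 1 at the digits shown, the two together the lowest of the three numbers; its nearest neighbour is compound 1, no change at the digits printed from compound 1 to compound 2 (within the scatter), and its furthest is compound 3, a number 47.7 percentage points higher from compound 2 to compound 3 (beyond the scatter).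

Compound 4 `Clc1ccccc1COc1nc2ccccc2s1` is not yet measured in this assay. It differs from compound 2 in one place: chloro in place of hydrogen on an aromatic carbon.

Going by the values given here, the step that bears most directly on this change is the one between compound 1 and compound 2, where bromo gave way to hydrogen on an aromatic carbon with no change within the scatter. The step from compound 2 to compound 3 concerns a different group, trifluoromethyl, and is taken as less relevant here. A halogen entering at the position of compound 4 is therefore expected to give a step of a number 0.1 percentage points higher from compound 2 to compound 4 (within the scatter) in this assay, that is, none beyond the scatter. For compound 4 the expected value in this assay is 52%, with a range from 35% to 70%.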

Compound 4, a percentage reported as inhibition, in the whole organism at one dose (the size of the read-out at that dose, not a potency): "not active" (no number reported)
Compound 4: no number reported, so the estimate cannot be set against anything.
By their numbers in this assay, from the lowest: compounds 1 and 2 (each within the scatter of the next); then compound 3.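

Going by these compounds alone, compound 4 is reported in this assay only as "not active", with no number, so no step from compound 2 to compound 4 can be read. The compounds shown leave open how far chloro stands numerically from hydrogen and bromo in this series. No measurement shown bears on a reason for this result.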